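The source may hold more compounds than are shown below. What is called first, only, known or untested is meant among the compounds shown, and "the series" means these compounds.

Measured so far in a functional assay on HT cells (Homo sapiens) for antiproliferative activity, read by fluorescence, with a stated time of 72 h; a higher number here means a weaker inhibitor of growth, a lower number a stronger inhibitor of growth:

compound 1, `CSc1nc(NCc2ccc(-c3ccccn3)cc2)c2[nH]nc(C(C)C)c2n1`, 783 nM
compound 2, `CC(C)c1n[nH]c2c(NCc3ccc(-c4ccccn4)cc3)nc(SCC3CNC(=O)O3)nc12`, 80 nM
compound 3, `CC(C)c1n[nH]c2c(NCc3ccc(-c4ccccn4)cc3)nc(SCC(C)(C)O)nc12`, 507 nM

Compound 3 holds the second highest of the three numbers. Its nearest neighbour is compound 1, and the gap between them, a 1.5-fold lower number from compound 1 to compound 3 (0.19 log units; within the scatter), lies within the scatter. The furthest is compound 2, and that gap, a 6.3-fold higher number from compound 2 to compound 3 (0.80 log units; beyond the scatter), lies beyond the scatter; the matching step a 9.8-fold lower number from compound 1 to compound 2 (0.99 log units; beyond the scatter) shows the same group mattering.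

Compound 4, `CC(C)c1n[nH]c2c(NCc3ccc(-c4ccccn4)cc3)nc(SCC(C)(C)N)nc12`, differs from compound 3 in one place: amino in place of hydroxy on a saturated chain carbon bound to three saturated chain carbons. Within the data shown here, none of the measured steps exchanges hydroxy for amino; the steps that are known all concern what sits on the saturated chain carbon bound to the sulfur, where a 2-oxo-1,3-oxazolidin-5-yl group gave a modest step and a 1-hydroxy-1-methylethyl group gave a step within the scatter. On that basis the expected step of a 1.3-fold lower number from compound 3 to compound 4 (0.10 log units; within the scatter) is small, with no direction clearly favoured, and compound 4 is expected to give about 400 nM in this assay, somewhere between 150 nM and 1200 nM.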

Compound 4, concentration for 50% growth inhibition: 85 nM
The estimate for compound 4 lay 4.7-fold (0.67 log units) above the measured number; measured number outside the range, below it.
By their numbers in this assay, from the lowest: compounds 2 and 4 (each within the scatter of the next); then compounds 3 and 1 (each within the scatter of the next).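

In this assay, the exchange of hydroxy for amino on a saturated chain carbon bound to three saturated chain carbons proves to be a real change, with a 6.0-fold lower number from compound 3 to compound 4 (0.78 log units; beyond the scatter), even though the two groups match in every count computed for them: heavy atoms, hydrogen-bond donors, hydrogen-bond acceptors and net charge. Where the 1-hydroxy-1-methylethyl group had left the number within the scatter of the hydrogen in compound 1, the 1-amino-1-methylethyl group gives a 9.2-fold lower number from compound 1 to compound 4 (0.96 log units; beyond the scatter), and its step against the ring-bearing 2-oxo-1,3-oxazolidin-5-yl group, a 1.1-fold higher number from compound 2 to compound 4 (0.03 log units; within the scatter), shows that an open-chain group can match that ring on a saturated chain carbon bound to a sulfur. Nothing available on these compounds accounts for the difference between hydroxy and amino.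

The compounds shown leave open whether the gain survives on a substituted amine, such as methylamino or dimethylamino, or on an acetamide, and how a carboxylic acid would fare on the same carbon. They also leave open whether the two methyl groups matter, which a plain 2-aminoethyl chain on the sulfur would test.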